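From phenoxy to phenyl: an expectation for compound 3

The source may hold more compounds than are shown below. What is called first, only, known or untested is meant among the compounds shown, and "the series" means these compounds.

Measured so far in a functional assay on A-431 cells (Homo sapiens) for inhibition, read by MTT assay; a lower number here means a stronger inhibitor of growth, a higher number a weaker inhibitor of growth:
Compound 1 `O=C(CCCCc1cn(Cc2ccc(Br)cc2)nn1)NO` gives 15400 nM 
Compound 2 `O=C(CCCCc1cn(Cc2ccc(Oc3ccccc3)cc2)nn1)NO` gives 9030 nM 

On these numbers compound 2 stands within the scatter of compound 1, so the two cannot be ranked. Compound 3 `O=C(CCCCc1cn(Cc2ccc(-c3ccccc3)cc2)nn1)NO` has not been measured. Its difference from compound 2 is phenyl in place of phenoxy on an aromatic carbon. Going by the values given here, only one measured step bears on this change, the exchange of bromo for phenoxy on an aromatic carbon, and it is small (a 1.7-fold lower number from compound 1 to compound 2 (0.23 log units; within the scatter)). With so little to go on, no shift beyond the scatter is expected in this assay, and no direction can be argued. The expected step is small (a 1.1-fold higher number from compound 2 to compound 3 (0.04 log units; within the scatter)). Compound 3 is estimated at 10000 nM (expected range 4500 nM to 20000 nM).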

Compound 3, concentration for 50% growth inhibition: 2990 nM
For compound 3 the middle estimate is 3.3-fold (0.52 log units) above the measured one, outside the stated range (below it).
By their numbers in this assay, from the lowest: compound 3; then compounds 2 and 1 (each within the scatter of the next).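

In this assay the exchange of phenoxy for phenyl gives a 3.0-fold lower number from compound 2 to compound 3 (0.48 log units; beyond the scatter) and so shows that the number can respond to the group on this aromatic carbon, which the earlier exchange of bromo for phenoxy, within the scatter, did not show. Phenyl also stands apart from bromo, with a 5.2-fold lower number from compound 1 to compound 3 (0.71 log units; beyond the scatter) at the same place, although phenoxy and bromo could not be ranked; the six-membered aromatic ring alone therefore does not set the number, since phenoxy carries it too and differs from phenyl by its oxygen. Nothing at hand explains why this exchange matters.

The compounds shown leave open whether a benzyl group, or an amine on the phenyl ring, would follow phenyl or phenoxy. They also leave open whether the step would hold with a longer chain in the shared core.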